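A few compounds are considered here, and "the series" means these few. Any claim that something is new, unique, unknown or untested is made for them only; others in the source may bear on it.

Working notes on the aldehyde and ketoamide series.

Within the data shown here, in an assay on isolated protein for inhibition of cathepsin S (Homo sapiens), read by fluorescence (on this read-out higher numbers stand for weaker inhibition and lower numbers for stronger inhibition), compound 2 `CC(NC(=O)c1cccc(C(F)(F)F)c1Cl)C(=O)C(N)=O` gives 30.9 nM, the second highest of the three numbers so far. Compound 1 `CC(C=O)NC(=O)c1cccc(C(F)(F)F)c1Cl` gives 110 nM; compound 3 `CC(NC(=O)c1ccc(OCc2ccccn2)c(C(F)(F)F)c1Cl)C(=O)C(N)=O` gives 4.8 nM. The two measured steps are a 3.6-fold lower number from compound 1 to compound 2 (0.55 log units; beyond the scatter) and a 6.4-fold lower number from compound 2 to compound 3 (0.81 log units; beyond the scatter).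

Compound 4 `CCC(C=O)NC(=O)c1cccc(C(F)(F)F)c1Cl` is not yet measured. It differs from compound 2 by 1-formylpropyl in place of 1-(carbamoylcarbonyl)ethyl on an amide-type nitrogen. The step from compound 1 to compound 2 bears directly on this change, since the carbamoylcarbonyl is given up again in compound 4; going back along that step points to a number higher than that of compound 2. Among the measured compounds shown here, the ethyl in place of methyl on the same carbon has no measured counterpart, so no direction is taken from it. A modest rise in this assay is therefore expected, bringing compound 4 near compound 1.

Compound 4 is expected to give 150 nM in this assay, within 50 nM to 450 nM. The expected step is a 4.9-fold higher number from compound 2 to compound 4 (0.69 log units; beyond the scatter).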

Compound 4, half-maximal inhibitory concentration: 31 nM
Estimate against measurement, compound 4: 4.8-fold (0.68 log units) above, outside the stated range (below it).
By their numbers in this assay, from the lowest: compound 3; then compounds 2 and 4 (each within the scatter of the next); then compound 1.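

In this assay, 1-formylpropyl in place of 1-(carbamoylcarbonyl)ethyl on the amide-type nitrogen gives a 1.0-fold higher number from compound 2 to compound 4 (0.00 log units; within the scatter), so the carbamoylcarbonyl is not required for a number in this range once the chain carbon carries the added methyl. Among these compounds, that methyl alone on the saturated chain carbon gives a 3.5-fold lower number from compound 1 to compound 4 (0.55 log units; beyond the scatter), the first measured step at this carbon, and it matches in size a 3.6-fold lower number from compound 1 to compound 2 (0.55 log units; beyond the scatter). Among the compounds shown here, nothing measured so far explains this result.

Still open, as far as these compounds go, is whether the methyl and the carbamoylcarbonyl add up in one compound, as a 1-(carbamoylcarbonyl)propyl group on the same nitrogen would show. Also open, from the compounds shown here alone, are how far a longer chain, such as a 1-formylbutyl group, carries this step, and whether (pyridin-2-yl)methoxy on the aromatic carbon has the same effect alongside 1-formylpropyl.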